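Removing the carbonyl from compound 2

A few compounds are considered here, and "the series" means these few. Any claim that something is new, unique, unknown or untested is made for them only; others in the source may bear on it.

Values in an ADME assay on MRC5 cells (Homo sapiens) for cytotoxicity, read by fluorescence and resazurin assay, with a stated time of 3 days; a lower number here means that less compound is needed, a higher number that more compound is needed for the effect:
- compound 1 `COC(=O)CCc1ccc(S(=O)(=O)n2c(C3(O)C=CC(=O)C=C3)cc3ccccc32)cc1`: 280 nM
- compound 2 `CN1CCN(C(=O)CCc2ccc(S(=O)(=O)n3c(C4(O)C=CC(=O)C=C4)cc4ccccc43)cc2)CC1`: 52 nM

Of the two measured compounds, compound 2 has the lower number, at 52 nM, and compound 1 lies above it by more than the scatter. The next compound, compound 3 `CN1CCN(CCCc2ccc(S(=O)(=O)n3c(C4(O)C=CC(=O)C=C4)cc4ccccc43)cc2)CC1`, keeps the shared core and differs from compound 2 in one place: (4-methylpiperazin-1-yl)methyl in place of (4-methylpiperazin-1-yl)carbonyl on a saturated chain carbon, two bonds along the chain from an aromatic carbon. The carbonyl of the side chain is thus replaced, while the 4-methylpiperazin-1-yl group remains.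

Going by the values given here, only one measured step bears on this change: a 5.4-fold lower number from compound 1 to compound 2 (0.73 log units; beyond the scatter). That step is indirect evidence, since it exchanged methoxy for 4-methylpiperazin-1-yl on a carbonyl carbon and left the carbonyl in place. Among the compounds with values here, no measured pair tests the loss of the carbonyl itself. In this assay, a step smaller than that one is therefore expected, probably not beyond the scatter, with a slight lean toward a lower number. The expected step is a 1.3-fold lower number from compound 2 to compound 3 (0.11 log units; within the scatter).

The estimated value for compound 3 is 40 nM, with an expected range of 12 nM to 130 nM.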

Compound 3, half-maximal effective concentration: 50 nM
Compound 3: the middle estimate sits 1.3-fold (0.10 log units) below what was measured, within the range that was stated.
By their numbers in this assay, from the lowest: compounds 3 and 2 (each within the scatter of the next); then compound 1.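

In this assay, the earlier step had exchanged methoxy for 4-methylpiperazin-1-yl with the carbonyl kept, whereas this one removes the carbonyl itself and gives a 1.0-fold lower number from compound 2 to compound 3 (0.02 log units; within the scatter), so at this place on the saturated chain (4-methylpiperazin-1-yl)methyl and (4-methylpiperazin-1-yl)carbonyl cannot be told apart. The step from the ester to the carbonyl-free compound, a 5.6-fold lower number from compound 1 to compound 3 (0.75 log units; beyond the scatter), lies beyond the scatter, so among these three compounds the lower numbers go with the 4-methylpiperazin-1-yl group whether or not the carbonyl is present, and none of the three goes against this. Nothing available here accounts for this result.

The compounds shown leave open whether the whole 4-methylpiperazin-1-yl ring is needed, or whether a morpholin-4-yl group or an open-chain dimethylamine at the end of the same chain would read the same way in this assay. Also open, going by these compounds, is how a shorter or longer chain carrying the 4-methylpiperazin-1-yl group would behave, and how a carboxylic acid in place of the methoxycarbonyl would compare.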